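Swapping Cyano for Amino on the Phenyl Ring

A few compounds are considered here, and "the series" means these few. Any claim that something is new, unique, unknown or untested is made for them only; others in the source may bear on it.

Measured compounds:
Compound 1 `Fc1ccc(C2(c3ccc(F)cc3)CNC(c3cccc(F)c3)=N2)cc1`: 10 nM
Compound 2 `N#Cc1cccc(C2=NC(c3ccc(F)cc3)(c3ccc(F)cc3)CN2)c1`: 2.7 nM

In an assay on LM cells for displacement of a labelled ligand from Neuropeptide Y receptor type 5 (Homo sapiens) (a lower number here means a stronger inhibitor, a higher number a weaker inhibitor), compound 2 has the lowest number of the two, and compound 1 stands nearest with its higher value. Among the compounds with values here, the only step seen so far is a 3.7-fold lower number from compound 1 to compound 2 (0.57 log units; beyond the scatter). Compound 3 `Nc1cccc(C2=NC(c3ccc(F)cc3)(c3ccc(F)cc3)CN2)c1` carries one change from compound 2: amino in place of cyano on an aromatic carbon. Within the data shown here, no measured step covers an amino group here, so the cyano-to-fluoro step is the only guide, and it shows that this position responds to substitution. Compound 3 is expected to give a weaker result, a 3.7-fold higher number from compound 2 to compound 3 (0.57 log units; beyond the scatter), with an estimate of 10 nM and a range from 2.5 nM to 40 nM.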

Compound 3, half-maximal inhibitory concentration: 300 nM
Compound 3: the middle estimate sits 30-fold (1.48 log units) below what was measured, and the stated range ends below it.
By their numbers in this assay, from the lowest: compound 2; then compound 1; then compound 3.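

In this assay, this position proves far more sensitive than the first pair suggested: amino in place of cyano gives a 110-fold higher number from compound 2 to compound 3 (2.05 log units; beyond the scatter), and amino in place of fluoro gives a 30-fold higher number from compound 1 to compound 3 (1.48 log units; beyond the scatter). Of the three groups tried here, amino therefore stands apart, with a much larger loss than the difference between fluoro and cyano. Nothing measured here explains this loss. As far as these compounds go, it remains open whether a methylamino group, a hydroxyl group or a carboxylic acid on this carbon would fare as poorly as amino, or whether an acetamide would recover the lost strength.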